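Methylthiophene swap from compound 3 to compound 4

The compounds below may be only part of what the source reports. "The series", "measured", "known", "first", "only" and "open" are said of these compounds alone.

Values in a functional assay on DU-145 cells (Homo sapiens) for inhibition, read by trypan blue exclusion, with a stated time of 96 h (on this read-out lower numbers stand for stronger inhibition of growth and higher numbers for weaker inhibition of growth), for the measured compounds
- compound 1 `Cc1ccsc1/C=C(/SCc1ccc(Cl)c(Cl)c1)C(=O)c1ccc(Cl)cc1` with 50000 nM
- compound 2 `Cc1ccsc1/C=C(/SCc1ccc(Cl)cc1Cl)C(=O)c1ccc(Cl)cc1` with 10000 nM
- compound 3 `Cc1ccc(/C=C(/SCc2ccc(F)cc2)C(=O)c2ccc(Cl)cc2)s1` with > 100000 nM as a limit

Compound 3 sits at the limit of > 100000 nM in this assay, at which 1 of the 3 values shown sits, and has no number of its own. The change to compound 4 `Cc1ccsc1/C=C(/SCc1ccc(F)cc1)C(=O)c1ccc(Cl)cc1` is 3-methylthiophen-2-yl in place of 5-methylthiophen-2-yl on a double-bonded chain carbon bound to a double-bonded chain carbon with 3-methylthiophen-2-yl in place of 5-methylthiophen-2-yl on a double-bonded chain carbon bound to a double-bonded chain carbon.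

Among the measured compounds shown here, no measured step tests this swap directly. For the measured compounds named here, the one measured step is a 5.0-fold lower number from compound 1 to compound 2 (0.70 log units; beyond the scatter) for 2,4-dichlorophenyl in place of 3,4-dichlorophenyl on a saturated chain carbon bound to a sulfur. It bears only indirectly, as a modest measure of how far a single change moves values here.

Compound 1 with 50000 nM and compound 2 with 10000 nM both carry the 3-methylthiophen-2-yl group and both give numbers, so a lower number is expected in this assay on this swap. The expected step is an at least 3.3-fold lower number from compound 3 to compound 4 (0.52 log units; beyond the scatter) and its size stays uncertain while one end is only a limit. For compound 4 the estimated value is 30000 nM with an expected range from 8000 nM to 100000 nM in this read-out.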

Compound 4, concentration for 50% growth inhibition: 50000 nM
Compound 4: middle estimate off by 1.7-fold (0.22 log units), on the low side; low and high end bracket the measured number.
By their numbers in this assay, from the lowest: compound 2; then compounds 1 and 4 (each within the scatter of the next). At a limit, above all of these: compound 3.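

In this assay, 3-methylthiophen-2-yl in place of 5-methylthiophen-2-yl on a double-bonded chain carbon bound to a double-bonded chain carbon gives an at least 2.0-fold lower number from compound 3 to compound 4 (0.30 log units; that floor lies within the scatter), so this swap can be read in direction only, with its true size unknown. The entry for compound 3 is a limit and not a number: the limit of > 100000 nM in this assay, at which 1 of the 4 values shown sits. With 3-methylthiophen-2-yl held constant, the aryl group on a saturated chain carbon bound to a sulfur now has three readable members, where 4-fluorophenyl in place of 2,4-dichlorophenyl gives a 5.0-fold higher number from compound 2 to compound 4 (0.70 log units; beyond the scatter) and 4-fluorophenyl in place of 3,4-dichlorophenyl gives no change at the digits printed from compound 1 to compound 4 (within the scatter), leaving 2,4-dichlorophenyl as the only one of the three set apart from the others by its lower number.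

Open, going by these compounds, is whether the thiophene swap runs the same way with 2,4-dichlorophenyl as it does with 4-fluorophenyl. Also open, on these data alone, is how an amine or a carboxylic acid in place of the methyl on the thiophene, or a longer chain in place of the saturated chain carbon bound to a sulfur, would read in this assay.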